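Swapping a chloro for methylsulfonyl on the aniline ring

The compounds below may be only part of what the source reports. "The series", "measured", "known", "first", "only" and "open" are said of these compounds alone.

Of the compounds shown here, two built on one shared core have been tested so far. Compound 1 `CN(c1nc2c(Nc3ccc(C(F)(F)F)cc3)ncnc2s1)c1c(Cl)cccc1Cl` gives 502 nM in a functional assay on HEK293 cells for antagonist activity at transient receptor potential cation channel subfamily V member 1 (Homo sapiens), read by calcium flux; a lower number here means a stronger inhibitor, a higher number a weaker inhibitor. Compound 2 `FC(F)(F)c1ccc(Nc2ncnc3sc(Nc4ccccc4Cl)nc23)cc1` gives 64 nM in this assay. Among the measured compounds shown here, the only change between them is (2-chlorophenyl)amino in place of (2,6-dichlorophenyl)(methyl)amino on an aromatic carbon, and it produced a 7.8-fold lower number from compound 1 to compound 2 (0.89 log units; beyond the scatter). Compound 2 is therefore the stronger inhibitor of the two, and the measured numbers show that this part of the molecule matters.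

Compound 3 `CS(=O)(=O)c1ccccc1Nc1nc2c(Nc3ccc(C(F)(F)F)cc3)ncnc2s1` has not yet been measured. It keeps everything in compound 2 except one group: methylsulfonyl in place of chloro on an aromatic carbon. For the measured compounds named here, no measured step involves this exchange, so the single step from compound 1 to compound 2 is only indirect guidance, showing that changes to this ring can move the number well beyond the scatter without saying in which direction a methylsulfonyl would move it. The expectation for compound 3 is therefore cautious: a modest shift of a 1.9-fold higher number from compound 2 to compound 3 (0.27 log units; within the scatter) with wide uncertainty. Compound 3 is estimated at 120 nM, within a range from 30 nM to 500 nM.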

Compound 3, half-maximal inhibitory concentration: 234 nM
Compound 3: the middle estimate sits 2.0-fold (0.29 log units) below what was measured; the measured number falls inside the stated range.
By their numbers in this assay, from the lowest: compound 2; then compound 3; then compound 1.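

In this assay, putting methylsulfonyl in place of chloro gives a 3.7-fold higher number from compound 2 to compound 3 (0.56 log units; beyond the scatter), so this exchange weakens inhibition by more than the usual scatter of repeated measurements. The earlier step altered more than one feature of this end of the molecule, whereas this one replaces a single group on an aromatic carbon, ortho to a large group, and so gives a direct reading of that group. The position accepts methylsulfonyl, with its four heavy atoms and two hydrogen-bond acceptors, in place of one chlorine, and compound 3 still gives 234 nM, but nothing measured here explains why the number rises.

As far as these compounds go, with only chloro and methylsulfonyl compared at this position, it remains open whether a fluorine, a methyl group or an amine in the same place would give a lower or a higher number than compound 2. From the compounds shown here alone, it is also open whether methylsulfonyl elsewhere on this ring, or the same exchange on a different core, would shift the number in the same direction.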